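The source may hold more compounds than are shown below. What is called first, only, known or untested is meant among the compounds shown, and "the series" means these compounds.

The series shares one core, seen in compound 1 `C#CCNC1CCc2c(SCc3ccc(Cl)cc3Cl)cccc21`, compound 2 `C#CCNC1CCc2c(SCCc3cccc(Br)c3)cccc21` and compound 3 `C#CCNC1CCc2c(OCc3cccc(C(F)(F)F)c3)cccc21`; the three differ in the side chain attached to that core. In an ADME assay on isolated protein for inhibition of Amine oxidase [flavin-containing] B (Homo sapiens) (a lower number here means a stronger inhibitor, a higher number a weaker inhibitor), compound 2 gives 620 nM, the lowest of the three numbers. Compound 3 gives 5410 nM, and compound 1 gives 22300 nM; both gaps to compound 2 lie beyond the scatter. Among the compounds with values here, no two measured compounds differ in a single place, so no single structural step can be read off from the measured set.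

Compound 4 `C#CCNC1CCc2c(SCCc3cccc(OC)c3)cccc21` is the next compound to go into this assay. It differs from compound 2 in one place: methoxy in place of bromo on an aromatic carbon. Within the data shown here, no measured pair shows this exchange, so the series gives no direct guide for it. The expected step of a 2.4-fold higher number from compound 2 to compound 4 (0.38 log units; beyond the scatter) in this assay is modest, toward a somewhat higher number, and may well stay within the scatter. The estimate for compound 4 in this assay is 1500 nM, with a range from 400 nM to 6000 nM; this rests on compound 2 giving 620 nM as the closest measured point.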

Compound 4, half-maximal inhibitory concentration: 3820 nM
The estimate for compound 4 lay 2.5-fold (0.41 log units) below the measured number, within the range that was stated.
By their numbers in this assay, from the lowest: compound 2; then compounds 4 and 3 (each within the scatter of the next); then compound 1.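

The exchange of bromo for methoxy gives the series its first step that can be read at a single place: in this assay it is a 6.2-fold higher number from compound 2 to compound 4 (0.79 log units; beyond the scatter). This shows that the aromatic carbon carrying the group, meta to a large group, is not indifferent to what stands on it, since with the rest of the structure held constant, 3-bromophenyl and 3-methoxyphenyl are separated by more than the scatter. No measurement on hand bears on what lies behind this step.

One exchange cannot show how the read-out ranks other groups at this carbon, so an amine, a carboxylic acid or a nitrile in the same place would each be a separate question. Going by these compounds, it also remains open whether the exchange would give a step of similar size with a longer chain in the side chain, or with the oxygen link of compound 3 in place of the sulfur link of compound 2.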